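Swapping an Isopropyl Amide for a Benzamide

The source may hold more compounds than are shown below. What is called first, only, known or untested is meant among the compounds shown, and "the series" means these compounds.

Measured compounds in an assay for inhibition of inositol hexakisphosphate kinase 3 (Homo sapiens), read by colorimetric assay, coupled enzyme assay and malachite green, with a stated time of 120 min, in the presence of a further agent that is not named here; on this read-out lower numbers stand for stronger inhibition and higher numbers for weaker inhibition:
compound 1, `O=C(O)c1ccc2noc(-c3ccc(-c4ccncc4)cc3)c2c1`, gives 670 nM
compound 2, `O=C(O)c1ccc2noc(-c3ccc(Oc4ncc(Cl)cc4Cl)cc3)c2c1`, gives 2250 nM
compound 3, `CC(C)C(=O)Nc1ccc(-c2onc3ccc(C(=O)O)cc23)cc1`, gives 210 nM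

Compound 3 stands at the lowest number of the three, which on this read-out means the strongest inhibition. Its nearest neighbour is compound 1, the step being a 3.2-fold lower number from compound 1 to compound 3 (0.50 log units; beyond the scatter); the step from compound 2 is larger still, an 11-fold lower number from compound 2 to compound 3 (1.03 log units; beyond the scatter). Both of these steps exchange the whole group attached to the aromatic carbon of the shared core's pendant ring, and both favour the (isopropylcarbonyl)amino group over a pyridin-4-yl or a (3,5-dichloropyridin-2-yl)oxy group.

Compound 4, `O=C(O)c1ccc2noc(-c3ccc(NC(=O)c4ccccc4)cc3)c2c1`, keeps that amide but alters what sits on its carbonyl carbon: phenyl in place of isopropyl on a carbonyl carbon. For the measured compounds named here, none of the measured steps touches this carbonyl substituent; they only show that the amide-bearing compound 3 did better than compounds 1 and 2. Going by the values given here, with no step of the same kind to lean on, the size of the change from compound 3 to compound 4 cannot be read from the data, and the expected step is a 1.2-fold higher number from compound 3 to compound 4 (0.08 log units; within the scatter), that is, no step beyond the scatter. Compound 4 is therefore estimated at 250 nM, with a range from 90 nM to 700 nM.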

Compound 4, half-maximal inhibitory concentration: 200 nM
Estimate against measurement, compound 4: 1.3-fold (0.10 log units) above, and the stated range covers the measured number.
By their numbers in this assay, from the lowest: compounds 4 and 3 (each within the scatter of the next); then compound 1; then compound 2.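

In this assay, phenyl in place of isopropyl on the carbonyl carbon gives a 1.1-fold lower number from compound 3 to compound 4 (0.02 log units; within the scatter) and so leaves the read-out within the usual scatter, which shows that this position takes a six-membered aromatic ring as readily as the smaller isopropyl. The better numbers seen for compound 3 therefore do not depend on isopropyl itself: the benzamido group also beats the pyridin-4-yl group with a 3.4-fold lower number from compound 1 to compound 4 (0.53 log units; beyond the scatter) and the (3,5-dichloropyridin-2-yl)oxy group with an 11-fold lower number from compound 2 to compound 4 (1.05 log units; beyond the scatter) and, among these four compounds, no compound goes against the two amides reading better than the other two groups. No measurement at hand offers an explanation for why the two amides read alike.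

Isopropyl and phenyl contain only carbon and hydrogen, so it remains open how this assay would read with a carbonyl substituent carrying an amine or a hydroxyl, or with a chlorine on the phenyl ring. The amide hydrogen and the carboxylic acid stay the same in compound 3 and compound 4, which leaves open what an N-methyl amide or a methyl ester in place of the acid would do.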